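One Group Exchanged on a Sulfonyl Sulfur

A few compounds are considered here, and "the series" means these few. Any claim that something is new, unique, unknown or untested is made for them only; others in the source may bear on it.

Compound 1 `O=C(NCc1ccc(S(=O)(=O)c2ccccc2C(F)(F)F)cc1)c1cc2cnccc2[nH]1` gives 41% in an ADME assay on microsomes from liver (Mus musculus) for metabolic stability, read by LC-MS, with a stated time of 30 min, tested at 1 uM; on this read-out higher numbers stand for a more stable compound and lower numbers for a less stable compound
Compound 2 `O=C(NCc1ccc(S(=O)(=O)c2ccccc2)cc1)c1ccc2cnccc2c1` gives 10% in this assay

Of these two numbers, compound 1 holds the higher, with 41% against compound 2 at 10%, a gap beyond the usual scatter of the measurement. Going by the values given here, no two measured compounds differ in only one place, so the data offer no measured step as a guide.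

Compound 3 `O=C(NCc1ccc(S(=O)(=O)c2ccc(F)c(F)c2)cc1)c1cc2cnccc2[nH]1` carries 3,4-difluorophenyl in place of 2-(trifluoromethyl)phenyl on a sulfonyl sulfur and is otherwise the same as compound 1. Both groups hold one six-membered aromatic ring of carbon only, and neither has a net charge. With nothing measured for this exchange, only a small step is expected in this assay, leaning slightly towards a lower number and staying within the scatter. The estimated change is a number 6 percentage points lower from compound 1 to compound 3 (within the scatter) and the uncertainty around it remains wide. For compound 3 the estimated value is 35%, with an expected range from 15% to 58%.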

Compound 3, percent of the compound remaining: 58%
Compound 3: the middle estimate sits 23 percentage points below what was measured; the range from low to high includes it.
By their numbers in this assay, from the lowest: compound 2; then compound 1; then compound 3.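

Going by these compounds alone, with 3,4-difluorophenyl in place of 2-(trifluoromethyl)phenyl on a sulfonyl sulfur, this assay gives a number 17 percentage points higher from compound 1 to compound 3 (beyond the scatter), and this is the first measured exchange in one place only. It shows that the aromatic group on the sulfonyl sulfur can by itself move the read-out beyond the scatter with the rest of compound 1 held constant, something the earlier pair could not show because its members differ in more than one place. Nothing available explains why this exchange raises the number.

Within the data shown here, the single exchange removes the trifluoromethyl group and brings in two fluorines at once, so it leaves open how much of the step belongs to the loss of one and how much to the arrival of the other. It also leaves open whether the number would hold with a methoxy group or an amine on that aromatic ring, and whether the same exchange would give a similar step on the core of compound 2.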